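Compound 3 to compound 4: butyl in place of amino

The source may report more compounds than this note shows. Statements on the series, on what has been measured and on what is new or still open speak of the compounds shown alone.

Measured in an ADME assay on HEK-293T cells (Homo sapiens) for cytotoxicity, read by luminescence, with a stated time of 24 h; a lower number here means that less compound is tolerated, a higher number that more compound is tolerated:
- compound 1 `CCN(CC)C(=O)c1cc2sccc2n1Cc1ccc(OC)cc1`: > 100000 nM
- compound 2 `COc1ccc(Cn2c(C(=O)N3CCCCC3)cc3sccc32)cc1`: > 100000 nM
- compound 3 `COc1ccc(Cn2c(C(=O)N3CCC(C(N)=O)CC3)cc3sccc32)cc1`: > 100000 nM

All three entries are limits of the assay and not numbers. Compound 3 stands at > 100000 nM, which is a limit. Going by the values given here, the series so far amounts to the limit of > 100000 nM in this assay, at which 3 of the 3 values shown sit.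

Compound 4 `CCCCC(=O)C1CCN(C(=O)c2cc3sccc3n2Cc2ccc(OC)cc2)CC1` carries butyl in place of amino on a carbonyl carbon, so that carbamoyl becomes butylcarbonyl: butyl in place of amino on a carbonyl carbon.

The closest measured change is a step that the two limits leave unreadable from compound 2 to compound 3, which concerns the same carbamoyl. Also relevant are a step that the two limits leave unreadable from compound 1 to compound 2 and a step that the two limits leave unreadable from compound 1 to compound 3. Among the compounds with values here, none of these has a readable size, and no measured compound carries butylcarbonyl, so any direction remains open. No step beyond the scatter is expected in this assay because a step that the two limits leave unreadable from compound 2 to compound 3 shows no departure from the limit, though a readable value for compound 4 cannot be excluded.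

The expected step is a number no higher from compound 3 to compound 4 (the limit leaves the size open). Compound 4 is estimated at 100000 nM, with an expected range of 35000 nM to 150000 nM.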

Compound 4, half-maximal cytotoxic concentration: 38900 nM
Compound 4: middle estimate off by 2.6-fold (0.41 log units), on the high side; the measured number falls inside the stated range.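

In this assay, going by these compounds alone, butyl in place of amino on a carbonyl carbon gives an at least 2.5-fold lower number from compound 3 to compound 4 (0.41 log units; beyond the scatter), so this substituent changes the read-out in a way the earlier compounds did not show. Butylcarbonyl gives an at least 2.5-fold lower number from compound 2 to compound 4 (0.41 log units; beyond the scatter), whereas carbamoyl at the same place shows no departure from the limit. Compound 4 alone gives a readable number, so this ring carbon tolerates some substitution without a readable effect but not all of it: the limit of > 100000 nM in this assay, at which 3 of the 4 values shown sit.

On these data alone, the full size of both steps stays open, and the steps among compound 1, compound 2 and compound 3 cannot be read. Whether a methyl group, a longer chain or a carboxylic acid in place of butyl would also leave the limit remains untested in the compounds shown.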